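A few compounds are considered here, and "the series" means these few. Any claim that something is new, unique, unknown or untested is made for them only; others in the source may bear on it.

Measured so far:

Compound 1, `C[C@@H]1CC[C@@H]2[C@@H](C1)OC(C)(C)C[C@@]2(C)O` — > 1410000 nM
Compound 2, `C[C@@H]1CC[C@@H]2[C@H](C1)OC1(CCCCCCC1)C[C@@]2(C)O` — 379000 nM
Compound 3, `CCCC1(CCC)C[C@@](C)(O)[C@@H]2CC[C@@H](C)C[C@@H]2O1` — 131000 nM

Of the compounds shown here, three have been tested in an ADME assay on MDCK cells (Canis lupus familiaris) for cytotoxicity, read by MTT assay, with a stated time of 48 h; a lower number here means that less compound is tolerated, a higher number that more compound is tolerated. Compound 1 gives only a limit in this assay, > 1410000 nM. Compound 2 gives 379000 nM in this assay, and compound 3 gives 131000 nM. Compound 1 therefore stands at the edge of what this assay can report, as summarised by the limit of > 1410000 nM in this assay, at which 1 of the 3 values shown sits; no number is known for it, only that it sits at this limit. Among the compounds with values here, no pair of measured compounds differs in a single place, so no measured step is available to guide the next one.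

Compound 4, `C[C@@H]1CC[C@@H]2[C@@H](C1)OC(C)(C)C[C@]2(C)O`, is the next compound to be measured in this assay. Its relation to compound 1 is the two compounds have the same atoms and bonds and differ only in configuration as drawn: 1 of 4 stereo elements differ; a stereocentre at a saturated ring carbon is drawn R in compound 1 and S in compound 4. With a change of this kind, and with compound 1 resting at a limit, no step beyond the usual scatter is expected; the step from compound 1 to compound 4 is estimated as an at least 1.4-fold lower number from compound 1 to compound 4 (0.14 log units; that floor lies within the scatter). Compound 4 is expected to give roughly 1000000 nM in this assay, with a likely range from 300000 nM to 3000000 nM, and a fair chance that it too is reported only as a limit.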

Compound 4, half-maximal cytotoxic concentration: 816000 nM
Estimate against measurement, compound 4: 1.2-fold (0.09 log units) above; the range from low to high includes it.
By their numbers in this assay, from the lowest: compound 3; then compound 2; then compound 4. At a limit, above all of these: compound 1.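

In this assay, within the data shown here, the inversion of one stereocentre at a saturated ring carbon, drawn R in compound 1 and S in compound 4, provides the first readable step, and that step is an at least 1.7-fold lower number from compound 1 to compound 4 (0.23 log units; that floor lies within the scatter). Compound 1 remains a limit and not a number, so this step is only a floor: the limit of > 1410000 nM in this assay, at which 1 of the 4 values shown sits. Any difference between the two compounds can rest only on that one stereocentre, and the floor of the step does not go beyond the scatter: the fact that compounds 1 and 4 differ only in the configuration as drawn.

The compounds shown leave open how large the true step is, and whether the same inversion would matter with the larger groups of compound 2 or compound 3. They also leave open how the number would respond to an amine or a carboxylic acid on the shared core.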